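This account rests on a few compounds, and the source may have more. Where it says the series, first, only, none or still open, it means among the compounds named here.

Of the compounds shown here, three of one shared core have been measured in a physicochemical assay for lipophilicity, measured as octanol-water partition (a higher number here means a more lipophilic compound, a lower number a more polar compound), so far. Compound 1, `NC(=O)c1nc2ccccn2c1[N+](=O)[O-]`, carries a carboxamide and in this assay compound 1 gives -0.515. Compound 2, `Cc1cccc2nc(NC3CCCCC3)c([N+](=O)[O-])n12`, carries a cyclohexylamino group and a methyl group, and in this assay compound 2 gives 1.56. Compound 3, `Cc1cccc2nc(C#N)c([N+](=O)[O-])n12`, carries a cyano group and a methyl group, and in this assay compound 3 gives 1.19.

On these three numbers compound 3 stands second highest: compound 2 lies above it by a gap beyond the usual scatter, and compound 1 lies far below it, again beyond the scatter.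

Compound 4, `CCOC(=O)c1nc2cccc(C)n2c1[N+](=O)[O-]`, has not yet been measured. It differs from compound 3 in one place: ethoxycarbonyl in place of cyano on an aromatic carbon.

Among the measured compounds shown here, no step between two measured compounds shows this exact exchange, so the expectation rests on the change itself. The ethoxycarbonyl group brings in more carbon atoms than the cyano group it replaces, and for compound 4 the step of a number 0.81 log units higher from compound 3 to compound 4 (beyond the scatter) in this assay is expected to be upward and beyond the scatter. Compound 4 is therefore estimated to give 2 in this assay, within a range from 1.5 to 2.5.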

Compound 4, partition coefficient: 1.27
Estimate against measurement, compound 4: 0.73 log units above, and the stated range ends above it.
By their numbers in this assay, from the lowest: compound 1; then compounds 3, 4 and 2 (each within the scatter of the next, the first and the last beyond it).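

In the measure used here (this assay) the exchange of cyano for ethoxycarbonyl, on the aromatic carbon next to the ring atom that bears a nitro group, gives a number 0.08 log units higher from compound 3 to compound 4 (within the scatter) and so the two groups cannot be told apart at this place. Among the compounds shown here, this is the first direct look at a single exchange on the shared core, which the earlier compounds could not give. The entering group has 5 heavy atoms, 3 of them carbon, against 2 heavy atoms, 1 of them carbon, in the group that leaves, so here a larger group with more carbon did not go with a reading outside the scatter, and nothing at hand explains why.

The compounds shown leave open whether other groups on this aromatic carbon, such as a carboxylic acid or a primary amine, would also stay within the scatter of compound 3. Also open, as far as these compounds go, is whether a longer chain on the ester, such as butyl in place of ethyl, would read the same as compound 4 on this core.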